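The source may hold more compounds than are shown below. What is called first, only, known or untested is meant among the compounds shown, and "the series" means these compounds.

In a functional assay on OVCAR-5 cells (Homo sapiens) for inhibition, read by sulforhodamine B assay, with a stated time of 48 h (on this read-out lower numbers stand for stronger inhibition of growth and higher numbers for weaker inhibition of growth), three compounds have been tested so far. Compound 1 (`CN(C)/C=C/C(=O)c1nn(-c2ccccc2)c(-c2ccccc2)c1C#N`) gives > 100000 nM as a limit of the assay and not as a number. Compound 2 (`N#Cc1c(-c2nnc(O)c3nn(-c4ccc(Cl)cc4)cc23)nn(-c2ccccc2)c1-c1ccccc1`) gives 32800 nM as a true measured number. Compound 3 (`N#Cc1c(-c2nnc(-c3nn(-c4ccccc4)c(-c4ccccc4)c3C#N)c3nn(-c4ccccc4)cc23)nn(-c2ccccc2)c1-c1ccccc1`) gives 9120 nM as the lower of the two numbers, and its gap to compound 2 lies beyond the scatter of repeated measurements.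

Compound 4 (`N#Cc1c(-c2nnc(-c3nn(-c4ccccc4)c(-c4ccccc4)c3C#N)c3nn(-c4ccc(Cl)cc4)cc23)nn(-c2ccccc2)c1-c1ccccc1`) has not yet been measured. It differs from compound 3 by a single change (chloro in place of hydrogen on an aromatic carbon) on an aromatic carbon, which turns a phenyl into a 4-chlorophenyl. Within the data shown here, no two measured compounds differ in only one place, so the data offer no direct guide to the size of this change. Compound 2 also carries a 4-chlorophenyl and gives 32800 nM in this test, but it differs from compound 3 in much more than that, so its number cannot show what the chloro alone does. A small step in this assay is therefore expected, within the scatter or slightly beyond it toward a lower number. The estimate amounts to an expected step of a 1.3-fold lower number from compound 3 to compound 4 (0.11 log units; within the scatter) in this modest range. For compound 4 the expected value is 7000 nM with an estimated range from 2500 nM to 20000 nM around it.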

Compound 4, concentration for 50% growth inhibition: > 100000 nM
Compound 4: no number, only a limit; the forecaster's own chance of this, stated with the estimate: 5%; middle value at least 14-fold (1.15 log units) away from the limit.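

Turning the phenyl of compound 3 into a 4-chlorophenyl gives an at least 10-fold higher number from compound 3 to compound 4 (1.04 log units; beyond the scatter) in this assay, which is the first direct reading of a single change in this series. It shows that one chlorine atom on an aromatic carbon, para to a large group, is enough to take a compound with a measured number out of the range that can be read. Compound 4 gives > 100000 nM, which is a limit of the assay and not a number, so the step has a known minimum but no known full size, and the limit is a common end point in this small set, because several values stop there: the limit of > 100000 nM in this assay, at which 2 of the 4 values shown sit.

On these data alone, what a fluoro, a bromo, a methyl or a methoxy group would do at this same place remains open, and so does whether the step belongs to chlorine alone or to any atom other than hydrogen. Also open, as far as these compounds go, is whether a chloro on one of the other phenyl rings of compound 3 would give a step of similar size.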